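Swapping One Thiazole Group for Another

The source may hold more compounds than are shown below. What is called first, only, known or untested is meant among the compounds shown, and "the series" means these compounds.

In a toxicity assay on HepG2 2.2.15 cells (Homo sapiens) for cytotoxicity, read by CellTiter-Glo (a lower number here means that less compound is tolerated, a higher number that more compound is tolerated), compound 1 `C[C@H]1Cn2ncc(N3CC(c4ccccc4)CC3=O)c2CN1S(=O)(=O)Nc1cc(F)c(F)c(F)c1` reads > 2000 nM, which is a limit of the assay and not a number. Within the data shown here, compound 2 `O=C1CC(c2cnc(C(F)(F)F)s2)CN1c1cnn2c1CN(C(=O)Nc1cc(F)c(F)c(F)c1)C(C1CC1)C2` gives 38500 nM, the only true number so far, so it has no measured neighbour to be ranked against. Compound 3 `Cc1cnc(C2CC(=O)N(c3cnn4c3CN(C(=O)Nc3cc(F)c(F)c(F)c3)C(C3CC3)C4)C2)s1` differs from compound 2 in one place: 5-methyl-1,3-thiazol-2-yl stands in place of 2-(trifluoromethyl)-1,3-thiazol-5-yl on a saturated ring carbon (5-methyl-1,3-thiazol-2-yl in place of 2-(trifluoromethyl)-1,3-thiazol-5-yl on a saturated ring carbon). Among the measured compounds shown here, no measured pair shows what such an exchange does in this assay, so no step beyond the usual scatter is expected, in either direction. The expected step is a 1.1-fold lower number from compound 2 to compound 3 (0.04 log units; within the scatter). This expectation rests on compound 2 at 38500 nM. For compound 3 the estimated value is 35000 nM, with an expected range from 13000 nM to 90000 nM.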

Compound 3, half-maximal cytotoxic concentration: 96200 nM
Compound 3: the middle estimate sits 2.7-fold (0.44 log units) below what was measured; the measured number lies above the stated range.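

In this assay, putting 5-methyl-1,3-thiazol-2-yl in place of 2-(trifluoromethyl)-1,3-thiazol-5-yl gives a 2.5-fold higher number from compound 2 to compound 3 (0.40 log units; beyond the scatter). This shows that the group on this saturated ring carbon can shift how much compound the cells tolerate, here modestly towards more being tolerated. Compound 1 cannot sharpen the picture, as it differs from the others in more than one place and its value is a limit: the limit of > 2000 nM in this assay, at which 1 of the 3 values shown sits.

This single pair changes both the ring atom through which the thiazole is joined and the group it carries, so it cannot tell which of the two drives the step. Also open, from the compounds shown here alone, is what a thiazole with no added group, or a different kind of group such as an amine or a carboxylic acid, would do on this carbon.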